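This account rests on a few compounds, and the source may have more. Where it says the series, first, only, none or still open, it means among the compounds named here.

Measured in an ADME assay on BaF3 cells (Mus musculus) for inhibition, read by CellTiter-Glo, with a stated time of 72 h; on this read-out lower numbers stand for stronger inhibition of growth and higher numbers for weaker inhibition of growth:
Compound 1 `Cc1cc(Nc2ncc3c(n2)N(C)C(=O)N(c2cc(NC(=O)c4ccc(CN5CCC(N(C)C)C5)c(C(F)(F)F)c4)ccc2C)C3)n(C)n1`: 509 nM
Compound 2 `CC(=O)N1CCN(c2ccc(Nc3ncc4c(n3)N(C)C(=O)N(c3cc(NC(=O)c5ccc(CN6CCC(N(C)C)C6)c(C(F)(F)F)c5)ccc3C)C4)cn2)CC1`: 187 nM
Compound 3 `Cc1ccc(Nc2ncc3c(n2)N(C2CC2)C(=O)N(c2cc(NC(=O)c4ccc(C)c(C(F)(F)F)c4)ccc2C)C3)cn1`: 649 nM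

Of these three, compound 2 has the lowest number, at 187 nM, and its gaps to both of the others lie beyond the scatter. Compound 4 `Cc1ccc(Nc2ncc3c(n2)N(C)C(=O)N(c2cc(NC(=O)c4ccc(CN5CCC(N(C)C)C5)c(C(F)(F)F)c4)ccc2C)C3)cn1` differs from compound 2 by one change, methyl in place of 4-acetylpiperazin-1-yl on an aromatic carbon, next to the ring nitrogen. Among the compounds with values here, no measured pair shows this change alone. Compound 1, which has no 4-acetylpiperazin-1-yl group, gives 509 nM. Compound 3 has methyl at the same place and gives 649 nM, but it also differs from compound 4 elsewhere. On these values, a moderate rise in this assay is expected, meaning weaker inhibition of growth, probably just beyond the scatter. The estimated change is a 2.1-fold higher number from compound 2 to compound 4 (0.33 log units; beyond the scatter). For compound 4 the expected value is 400 nM, with an estimated range of 150 nM to 1000 nM.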

Compound 4, concentration for 50% growth inhibition: 636 nM
Compound 4: the middle estimate sits 1.6-fold (0.20 log units) below what was measured; the range from low to high includes it.
By their numbers in this assay, from the lowest: compound 2; then compounds 1, 4 and 3 (each within the scatter of the next).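

In this assay, the change from 4-acetylpiperazin-1-yl to methyl on the aromatic carbon next to the ring nitrogen can now be read alone, as a 3.4-fold higher number from compound 2 to compound 4 (0.53 log units; beyond the scatter), so the lower number of compound 2 goes with the larger group at this place. The other single change, 6-methylpyridin-3-yl in place of 1,3-dimethyl-1H-pyrazol-5-yl on a nitrogen on an aromatic ring, gives a 1.2-fold higher number from compound 1 to compound 4 (0.10 log units; within the scatter), so these two small aryl groups cannot be told apart in this assay. The data shown offer no evidence on what lies behind the step from the 4-acetylpiperazin-1-yl group.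

The compounds shown leave open whether the acetyl group or the piperazine ring goes with the lower number. A piperazine without the acetyl, a 4-methylpiperazin-1-yl group or a morpholine at this place would separate the two.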